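The source may report more compounds than this note shows. Statements on the series, on what has been measured and on what is new or still open speak of the compounds shown alone.

Measured compounds:
- compound 1, `Brc1ccc(OC[C@@H]2CCN2)cn1`: 0.021 nM
- compound 2, `Brc1cncc(OC[C@@H]2CCN2)c1`: 0.18 nM

Both values come from an assay on brain for binding affinity to Neuronal acetylcholine receptor; alpha4/beta2 (Rattus norvegicus), read by radioligand binding; on this read-out higher numbers stand for weaker inhibition and lower numbers for stronger inhibition. Among the measured compounds shown here, of the two numbers, compound 2 stands at the higher one, meaning weaker binding; the only neighbour, compound 1, sits below it by a margin beyond the usual scatter, so the two compounds are genuinely told apart by this assay. The pair differs in more than one place, so nothing can be said about which part of the structure accounts for that gap.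

The next compound, compound 3, `CC(=O)NCc1cncc(OC[C@@H]2CCN2)c1`, has not been measured. It is made from compound 2 by a single change: acetamidomethyl in place of bromo on an aromatic carbon. No comparable change has been measured in this series, so the expectation below rests on the size and direction typical of such a swap rather than on a measured step. A moderate rise in the number, that is weaker binding, is expected; the step of an 8.3-fold higher number from compound 2 to compound 3 (0.92 log units; beyond the scatter) is the size estimated.

Compound 3 is expected to give about 1.5 nM in this assay, most likely between 0.3 nM and 8 nM.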

Compound 3, inhibition constant: 0.54 nM
Beside the measured number, compound 3's estimate is 2.8-fold (0.44 log units) above it, and the stated range covers the measured number.
By their numbers in this assay, from the lowest: compound 1; then compound 2; then compound 3.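

In this assay, among the compounds shown here, putting acetamidomethyl in place of bromo gives a 3.0-fold higher number from compound 2 to compound 3 (0.48 log units; beyond the scatter), the first measured change that touches only one place. The step is modest but real, and it shows that this aromatic carbon, two atoms from the ring nitrogen, tolerates a swap from 1 heavy atom to 5, with a hydrogen-bond donor and a hydrogen-bond acceptor added, while compound 3 still reads 0.54 nM. No measurement available here explains why the number rises.

The compounds shown leave open which part of the acetamidomethyl group accounts for the step, and a plain aminomethyl group, a simple methyl group or a longer chain ending in an amide at this carbon would help to separate the effect of the chain from that of the carbonyl and the amide hydrogen. Also open, from the compounds shown here alone, is how bromo and acetamidomethyl would each compare with a bare hydrogen at this carbon, which would show whether either group adds to binding or only takes away from it.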